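Cytotoxicity notes on a bridged diphenyl amine series

A few compounds are considered here, and "the series" means these few. Any claim that something is new, unique, unknown or untested is made for them only; others in the source may bear on it.

Compound 1 `CN(C)C12CCN(CCCN3CCCCC3)C(C(c3ccccc3)C1)C(c1ccccc1)C2` and compound 2 `CN(C)C12CCN(C(=O)CCN3CCCCC3)C(C(c3ccccc3)C1)C(c1ccccc1)C2` share one core and differ only in the chain on the ring nitrogen. In an ADME assay on L6 cells (Rattus norvegicus) for cytotoxicity (on this read-out lower numbers stand for stronger inhibition and higher numbers for weaker inhibition), compound 1 gives 58400 nM. Going by the values given here, in the same read-out compound 2 gives 128000 nM, the highest of the two numbers measured so far; its nearest neighbour is compound 1, and the single step on record, a 2.2-fold higher number from compound 1 to compound 2 (0.34 log units; beyond the scatter), lies beyond the scatter.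

Compound 3 `O=C(CCN1CCCCC1)N1CCC2(N3CCCCC3)CC(c3ccccc3)C1C(c1ccccc1)C2` keeps the amide-bearing chain of compound 2 and alters a different site: piperidin-1-yl in place of dimethylamino on a saturated ring carbon. Among the compounds with values here, no measured step touches this saturated ring carbon; the only measured step concerns the ring nitrogen and so gives no direct guide to the size or direction of the present change. With nothing further to go on, no step beyond the scatter is expected in this assay for this change, and the range is kept wide.

Compound 3 is therefore estimated at 128000 nM, with a range from 45000 nM to 360000 nM. The expected step, no change at the digits printed from compound 2 to compound 3 (within the scatter), is within the scatter.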

Compound 3, half-maximal inhibitory concentration: 63900 nM
The estimate for compound 3 lay 2.0-fold (0.30 log units) above the measured number; the range from low to high includes it.
By their numbers in this assay, from the lowest: compounds 1, 3 and 2 (each within the scatter of the next, the first and the last beyond it).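

Going by these compounds alone, at the saturated ring carbon of the shared core, piperidin-1-yl in place of dimethylamino gives, in this assay, a 2.0-fold lower number from compound 2 to compound 3 (0.30 log units; within the scatter), the first reading of any change at this position. With the amide-bearing chain of compound 2 in place, this position therefore takes a six-membered non-aromatic ring instead of the open-chain dimethylamino group without a step beyond the scatter, although one pair gives no trend for the position as a whole. Nothing on hand accounts for the size of this step or for the earlier step on the ring nitrogen.

Going by these compounds, whether a smaller or differently built amine at this carbon, such as pyrrolidin-1-yl, morpholin-4-yl or a primary amine, would move the number beyond the scatter remains open. Also open, on these data alone, is whether piperidin-1-yl at this carbon would behave in the same way alongside the 3-(piperidin-1-yl)propyl chain of compound 1, and whether changes to the two phenyl groups would shift the cytotoxicity read-out further.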